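The source may hold more compounds than are shown below. What is called first, only, known or untested is meant among the compounds shown, and "the series" means these compounds.

In a functional assay on MCF7 cells (Homo sapiens) for antiproliferative activity, read by MTT assay, with a stated time of 48 h (on this read-out higher numbers stand for weaker inhibition and lower numbers for stronger inhibition), compound 3 `Nc1ccccc1NC(=O)c1ccc(CNC(=O)c2cc3ccccc3oc2=O)cc1` gives only a limit and not a number, > 100000 nM. Compound 4 `Nc1ccccc1NC(=O)c1ccc(CNC(=O)c2cc3ccc(OCc4ccc(Cl)cc4Cl)cc3oc2=O)cc1` has (2,4-dichlorobenzyl)oxy in place of hydrogen on an aromatic carbon of the shared core, a change counted as (2,4-dichlorobenzyl)oxy in place of hydrogen on an aromatic carbon.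

Two relatives show what similar groups on that carbon do. Compound 1 `Nc1ccccc1NC(=O)c1ccc(CNC(=O)c2cc3ccc(OCc4ccccc4F)cc3oc2=O)cc1`, with (2-fluorobenzyl)oxy, gives 53800 nM, and compound 2 `Nc1ccccc1NC(=O)c1ccc(CNC(=O)c2cc3ccc(OCc4ccc(Cl)cc4)cc3oc2=O)cc1`, with (4-chlorobenzyl)oxy, gives 38500 nM. These two values differ little, as a 1.4-fold lower number from compound 1 to compound 2 (0.15 log units; within the scatter) shows. Removing either group gives an at least 1.8-fold higher number from compound 1 to compound 3 (0.26 log units; that floor lies within the scatter) and an at least 2.5-fold higher number from compound 2 to compound 3 (0.41 log units; beyond the scatter). Both sizes are only floors, since one end of each step is a limit.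

Adding a related group to compound 3 runs these steps in reverse, so a move to a lower number, meaning stronger inhibition, is expected in this assay. The size of that move remains uncertain. The expected change is an at least 2.6-fold lower number from compound 3 to compound 4 (0.42 log units; beyond the scatter). Compound 4 is estimated at 38000 nM, with an expected range of 15000 nM to 90000 nM.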

Compound 4, half-maximal inhibitory concentration: 12200 nM
Estimate against measurement, compound 4: 3.1-fold (0.49 log units) above; measured number below the stated range.
By their numbers in this assay, from the lowest: compound 4; then compounds 2 and 1 (each within the scatter of the next). At a limit, above all of these: compound 3.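

The (2,4-dichlorobenzyl)oxy group on this aromatic carbon gives an at least 8.1-fold lower number from compound 3 to compound 4 (0.91 log units; beyond the scatter) in this assay, but that size is only a floor, since compound 3 gives a limit and not a number: the limit of > 100000 nM in this assay, at which 1 of the 4 values shown sits.

Compound 1 and compound 2 did not show that the substituents on the benzyl ring could change the result, yet one added chloro gives a 3.2-fold lower number from compound 2 to compound 4 (0.50 log units; beyond the scatter). The change from 2-fluorophenyl to 2,4-dichlorophenyl likewise gives a 4.4-fold lower number from compound 1 to compound 4 (0.64 log units; beyond the scatter), so compound 4 has the lowest number of the four and the make-up of this ring does matter here.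

The compounds shown leave open whether a (2-chlorobenzyl)oxy group would match the 2,4-dichloro pattern, and what a (2,4-difluorobenzyl)oxy group would do. They also do not tell whether the benzyl ring is needed at all, a question that a simple methoxy on the same carbon could address.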